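Swapping a methoxyphenyl amide for a pyridyl amide

The source may hold more compounds than are shown below. What is called first, only, known or untested is meant among the compounds shown, and "the series" means these compounds.

Measured compounds:
compound 1 `CCC(=O)Nc1ncc(-c2ccc(OC)cc2)n1C` gives > 100000 nM
compound 2 `COc1ccc(-c2cnc(NC(=O)c3cccc(Cl)c3)n2C)cc1` gives > 28000 nM
compound 3 `COc1ccc(-c2cnc(NC(=O)c3cccc(OC)c3)n2C)cc1` gives > 100000 nM

All three share one core and differ only in the group on the carbonyl carbon of the amide. In a toxicity assay on THP-1 cells (Homo sapiens) for inhibition (a higher number here means that more compound is tolerated, a lower number that less compound is tolerated), compound 1 reaches only a limit, > 100000 nM. For compound 2 the result is also a limit, > 28000 nM. Compound 3, too, shows no number but a limit, > 100000 nM, so it stands among the best-tolerated compounds as far as the numbers reach. The steps a step that the two limits leave unreadable from compound 1 to compound 3 and a step that the two limits leave unreadable from compound 2 to compound 3 can therefore not be read in size: two limits bracket each of them (the limit of > 100000 nM in this assay, at which 2 of the 3 values shown sit, (the limit of > 28000 nM in this assay, at which 1 of the 3 values shown sits)).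

Compound 4 `COc1ccc(-c2cnc(NC(=O)c3ccncc3)n2C)cc1` changes the amide once more: pyridin-4-yl in place of 3-methoxyphenyl on a carbonyl carbon. Among the measured compounds shown here, no measured step follows this exact exchange, and the two steps that touch compound 3 are unreadable. For the measured compounds named here, since no compound among the three shows any measurable toxicity, compound 4 is expected to behave the same way, with a step of about a number no higher from compound 3 to compound 4 (the limit leaves the size open), that is none beyond the scatter. For compound 4 the estimate is 100000 nM, with a range from 30000 nM to 300000 nM, most likely reported again as a limit.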

Compound 4, half-maximal cytotoxic concentration: > 100000 nM
Compound 4: a limit, no number; the forecaster's own chance of this, stated with the estimate: 85%; the middle value lies on the limit itself.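

In this assay compound 4 gives > 100000 nM, which is a limit and not a number. Its steps from compound 1, compound 2 and compound 3 therefore cannot be read in size. The compounds shown leave open at what concentration, if any, each of these four amides becomes toxic to the cells.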